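Replacing nitro with fluoro in a sulfonyl series

This account rests on a few compounds, and the source may have more. Where it says the series, first, only, none or still open, it means among the compounds named here.

Measured in a functional assay on HepG2 cells (Homo sapiens) for antiproliferative activity, read by MTT assay, with a stated time of 24 h; a higher number here means a weaker inhibitor, a lower number a stronger inhibitor:
compound 1 `COc1ccc(S(=O)(=O)n2c(-c3cn(-c4ccccc4)nc3-c3ccc(C(F)(F)F)cc3)nc3ccccc32)cc1` gives 370 nM
compound 2 `Cc1ccc(C)c(S(=O)(=O)n2c(-c3cn(-c4ccccc4)nc3-c3ccc(C(F)(F)F)cc3)nc3ccccc32)c1` gives 330 nM
compound 3 `O=[N+]([O-])c1ccc(S(=O)(=O)n2c(-c3cn(-c4ccccc4)nc3-c3ccc(C(F)(F)F)cc3)nc3ccccc32)cc1` gives 1070 nM

Among these three, compound 3 has the highest number and is the weakest, with its gap to each of the others beyond the scatter. The next compound to be tested is compound 4 `O=S(=O)(c1ccc(F)cc1)n1c(-c2cn(-c3ccccc3)nc2-c2ccc(C(F)(F)F)cc2)nc2ccccc21` and it carries fluoro in place of nitro on an aromatic carbon, para to a large group: fluoro in place of nitro on an aromatic carbon is the whole of the difference.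

Among the measured compounds shown here, no fluoro compound has been measured yet, so the evidence is indirect. The step of a 1.1-fold lower number from compound 1 to compound 2 (0.05 log units; within the scatter) shows that the two compounds without nitro lie together in this assay despite their different sulfonyl substituents. Both steps that lead to the nitro compound are modest and raise the number: a 2.9-fold higher number from compound 1 to compound 3 (0.46 log units; beyond the scatter) and a 3.2-fold higher number from compound 2 to compound 3 (0.51 log units; beyond the scatter) are the measured sizes. Removing nitro is therefore expected to give a modest step of similar size towards a lower number, although a smaller one would not surprise. The step expected here is a 2.5-fold lower number from compound 3 to compound 4 (0.40 log units; beyond the scatter) as an estimate. For compound 4 the estimated value is 430 nM with an expected range from 200 nM to 900 nM in this series.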

Compound 4, half-maximal inhibitory concentration: 2730 nM
For compound 4 the middle estimate is 6.3-fold (0.80 log units) below the measured one; measured number outside the range, above it.
By their numbers in this assay, from the lowest: compounds 2 and 1 (each within the scatter of the next); then compound 3; then compound 4.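

In this assay, dropping nitro from this carbon, para to a large group, does not by itself lower the number: fluoro in place of nitro gives a 2.6-fold higher number from compound 3 to compound 4 (0.41 log units; beyond the scatter), so the nitro compound is no longer the weakest and compound 4 now holds that place, beyond the scatter of all three others. The gap to the two compounds at the low end is wider still, with fluoro in place of methoxy on the same carbon giving a 7.4-fold higher number from compound 1 to compound 4 (0.87 log units; beyond the scatter) and 4-fluorophenyl in place of 2,5-dimethylphenyl on the sulfonyl sulfur giving an 8.3-fold higher number from compound 2 to compound 4 (0.92 log units; beyond the scatter), so among the three groups on this carbon the order from the lowest number runs methoxy, nitro, fluoro, and the single-atom group stands at the high end. Nothing available here accounts for this order.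

What the compounds shown leave open is where an amine or a carboxylic acid on this same carbon would fall relative to methoxy and fluoro. They also leave open whether chloro or a longer chain such as ethoxy would stay near compound 1 or move towards compound 4.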